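The compounds below may be only part of what the source reports. "The series", "measured", "known", "first", "only" and "open" are said of these compounds alone.

Compound 1 `C#Cc1cn([C@@H]2O[C@H](CO)[C@@H](O)[C@H]2O)c2ncnc(NC)c12`: > 20000 nM
Compound 2 `Cc1ncnc2c1c(-c1cccs1)cn2[C@@H]1O[C@H](CO)[C@@H](O)[C@H]1O`: > 20000 nM

Both compounds were tested in a functional assay on K562 cells (Homo sapiens), read by MTT assay, with a stated time of 72 h; on this read-out lower numbers stand for stronger inhibition and higher numbers for weaker inhibition. Compound 2 gives > 20000 nM, which is a limit of the assay and not a number. Compound 1 gives > 20000 nM, which is also a limit. This is the limit of > 20000 nM in this assay, at which 2 of the 2 values shown sit, so the two compounds cannot be ranked against each other.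

Compound 3 `C#Cc1cn([C@@H]2O[C@H](CO)[C@@H](O)[C@H]2O)c2ncnc(C)c12` carries ethynyl in place of thiophen-2-yl on an aromatic carbon of the core of compound 2: ethynyl in place of thiophen-2-yl on an aromatic carbon. Among the measured compounds shown here, no measured pair shows this change on its own. Compound 1 also bears ethynyl and reaches only the limit of > 20000 nM, so only a modest move toward stronger inhibition is expected, and another limit is quite possible. The expected change is an at least 2.0-fold lower number from compound 2 to compound 3 (0.30 log units; that floor lies within the scatter). For compound 3 the estimated half-maximal inhibitory concentration is 10000 nM, with an expected range of 1000 nM to 20000 nM.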

Compound 3, half-maximal inhibitory concentration: 6920 nM
The estimate for compound 3 lay 1.4-fold (0.16 log units) above the measured number; low and high end bracket the measured number.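

In this assay, compound 3 is the only compound shown that gives a number rather than a limit, and both of its neighbours differ from it in a single place. With methyl kept on the core, ethynyl in place of thiophen-2-yl on the aromatic carbon gives an at least 2.8-fold lower number from compound 2 to compound 3 (0.46 log units; beyond the scatter), while with ethynyl kept, methyl in place of methylamino gives an at least 2.8-fold lower number from compound 1 to compound 3 (0.46 log units; beyond the scatter), so ethynyl at this position gives a measurable number here only alongside methyl, not alongside methylamino. Both steps are floors and their true sizes cannot be read, because compound 1 and compound 2 each sit at a limit: the limit of > 20000 nM in this assay, at which 2 of the 3 values shown sit.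

As far as these compounds go, it remains open whether a nitrile or a longer alkyne such as propynyl on that aromatic carbon would move the number further from that of compound 3. The same holds for a primary amine or a methoxy group in place of the methyl.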